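A Chain Change After Two Assay Limits

A few compounds are considered here, and "the series" means these few. Any claim that something is new, unique, unknown or untested is made for them only; others in the source may bear on it.

In a functional assay on A549 cells (Homo sapiens) for antiproliferative activity, read by MTT assay, with a stated time of 48 h (a lower number here means a stronger inhibitor, a higher number a weaker inhibitor), compound 1 `Cn1cc(C2=C(c3nn(CCCn4ccnc4)c4ncccc34)C(=O)NC2=O)c2ccccc21` gives > 100000 nM, which is a limit of the assay. Compound 2 `Cn1cc(C2=C(c3nn(CCCN4CCCCC4)c4ncccc34)C(=O)NC2=O)c2ccccc21` gives > 100000 nM, which is also a limit. Among the measured compounds shown here, the one measured step is a step that the two limits leave unreadable from compound 1 to compound 2. Compound 3 `Cn1cc(C2=C(c3nn(CCCCn4ccnc4)c4ncccc34)C(=O)NC2=O)c2ccccc21` carries (1H-imidazol-1-yl)methyl in place of piperidin-1-yl on a saturated chain carbon, three bonds along the chain from an aromatic nitrogen. Compound 1 and compound 2 both stand at the limit of > 100000 nM in this assay, at which 2 of the 2 values shown sit, so no step beyond the scatter is expected. The estimated change is a number no higher from compound 2 to compound 3 (the limit leaves the size open). Compound 3 is expected at 100000 nM, with an estimated range of 30000 nM to 150000 nM.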

Compound 3, half-maximal inhibitory concentration: 2380 nM
Beside the measured number, compound 3's estimate is 42-fold (1.62 log units) above it, outside the stated range (below it).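

In this assay, among the compounds shown here, (1H-imidazol-1-yl)methyl in place of piperidin-1-yl gives an at least 42-fold lower number from compound 2 to compound 3 (1.62 log units; beyond the scatter), the first readable change at this place on the chain. With the imidazole ring present on both sides, (1H-imidazol-1-yl)methyl in place of 1H-imidazol-1-yl gives an at least 42-fold lower number from compound 1 to compound 3 (1.62 log units; beyond the scatter), so the ring on the shorter chain does not by itself bring a readable value. Of the three compounds, only compound 3 has left the limit: the limit of > 100000 nM in this assay, at which 2 of the 3 values shown sit.

On these data alone, whether 4-(piperidin-1-yl)butyl would also leave the limit remains open. So does the effect of a longer chain, or of a primary amine in place of the imidazole ring.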